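This account rests on a few compounds, and the source may have more. Where it says the series, first, only, none or still open, it means among the compounds named here.

In an ADME assay on microsomes from liver (Mus musculus) for metabolic stability, using NADPH, with a stated time of 10 min (a lower number here means that less of the compound is left, a higher number that more of the compound is left), compound 1 (`c1cnc2c(c1)CN[C@@H](CN(CCCCNC1COC1)[C@H]1CCCc3cccnc31)C2`) gives 41% and compound 2 (`c1cnc2c(c1)CN[C@@H](CN(CCCCN(C1COC1)C1COC1)[C@H]1CCCc3cccnc31)C2`) gives 33%. For the measured compounds named here, compound 2 therefore stands within the scatter of compound 1, the only other measured compound. Compound 3 (`c1cnc2c(c1)CN[C@@H](CN(CCCC1CCNCC1)[C@H]1CCCc3cccnc31)C2`) differs from compound 2 by one change: a group of 6 heavy atoms (5 carbon, 1 nitrogen; one six-membered non-aromatic ring with 1 hetero atom) in place of a group of 10 heavy atoms (7 carbon, 1 nitrogen, 2 oxygen; 2 four-membered non-aromatic rings with 1 hetero atom each), on a saturated chain carbon, three bonds along the chain from an amine nitrogen. Going by the values given here, the only measured step bearing on this is a number 8 percentage points lower from compound 1 to compound 2 (within the scatter), which alters the same group but is a smaller change and sets no direction. No step beyond the scatter is expected in this assay, and the estimated step is a number 5 percentage points higher from compound 2 to compound 3 (within the scatter). Compound 3 is estimated at 38%, with an expected range from 20% to 58%.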

Compound 3, percent of the compound remaining: 69%
Compound 3: middle estimate off by 31 percentage points, on the low side; the measured number lies above the stated range.
By their numbers in this assay, from the lowest: compounds 2 and 1 (each within the scatter of the next); then compound 3.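

In this assay, the group on this saturated chain carbon clearly matters: piperidin-4-yl gives a number 36 percentage points higher from compound 2 to compound 3 (beyond the scatter) and also a number 28 percentage points higher from compound 1 to compound 3 (beyond the scatter), whereas the earlier change on the amine nitrogen stayed within the scatter. No measurement available here accounts for this rise.

Each step replaces a whole group at once, so the contributions of the ring and its amine nitrogen remain unseparated. Going by these compounds, whether the rise persists with a carboxylic acid or a longer chain at this place remains open.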